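Chloro for Trifluoromethyl on the Methoxy-Bearing Compound

The source may hold more compounds than are shown below. What is called first, only, known or untested is meant among the compounds shown, and "the series" means these compounds.

All of the measured compounds built on one shared core were run in a functional assay on T47D cells (Homo sapiens) for inhibition, read by sulforhodamine B assay, with a stated time of 48 h, tested at 100 uM; on this read-out lower numbers stand for a stronger effect and higher numbers for a weaker effect at the one concentration tested. Compound 1 `O=C(Nc1cccc(-n2cc(-c3ccncc3)c(-c3cc(O)cc(Cl)c3)n2)c1)Nc1ccc(Cl)c(C(F)(F)F)c1` gives -52% in this assay. Compound 2 `O=C(Nc1cccc(-n2cc(-c3ccncc3)c(-c3cc(O)cc(Cl)c3)n2)c1)Nc1ccc(Cl)c(Cl)c1` gives -39% in this assay. Compound 3 `COc1cc(Cl)cc(-c2nn(-c3cccc(NC(=O)Nc4ccc(Cl)c(C(F)(F)F)c4)c3)cc2-c2ccncc2)c1` gives -18% in this assay, the highest of these numbers, with its distance to each of the other two beyond the scatter. The two steps that connect the measured compounds are a number 13 percentage points higher from compound 1 to compound 2 (beyond the scatter) and a number 34 percentage points higher from compound 1 to compound 3 (beyond the scatter).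

Compound 4 `COc1cc(Cl)cc(-c2nn(-c3cccc(NC(=O)Nc4ccc(Cl)c(Cl)c4)c3)cc2-c2ccncc2)c1` has not yet been measured. It differs from compound 3 in one place: chloro in place of trifluoromethyl on an aromatic carbon. The same exchange of chloro for trifluoromethyl has been seen once before, in the step of a number 13 percentage points higher from compound 1 to compound 2 (beyond the scatter), a modest rise beyond the scatter. On that single precedent, a rise of similar size is expected for compound 4, namely a number 13 percentage points higher from compound 3 to compound 4 (beyond the scatter). Compound 4 is therefore estimated to give -5% in this assay, within a range from -25% to 15%.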

Compound 4, a percentage reported as activity, at one concentration (the size of the read-out at that concentration, not a potency): -9%
Compound 4: the middle estimate sits 4 percentage points above what was measured; the measured number falls inside the stated range.
By their numbers in this assay, from the lowest: compound 1; then compound 2; then compounds 3 and 4 (each within the scatter of the next).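

In this assay, chloro in place of trifluoromethyl on the methoxy-bearing core gives a number 9 percentage points higher from compound 3 to compound 4 (within the scatter), so here the exchange does not separate the pair, although it separated compound 1 from compound 2. Even so, the two readings of this change agree with each other: the same change on two cores in this assay, a number 13 percentage points higher (beyond the scatter) from compound 1 to compound 2 and a number 9 percentage points higher (within the scatter) from compound 3 to compound 4, 4 percentage points apart, within the scatter of two such steps Methyl in place of hydrogen on the oxygen, earlier seen only with trifluoromethyl present, now also gives a number 30 percentage points higher from compound 2 to compound 4 (beyond the scatter) with chloro present, and its size carries over: the same change on two cores in this assay, a number 34 percentage points higher (beyond the scatter) from compound 1 to compound 3 and a number 30 percentage points higher (beyond the scatter) from compound 2 to compound 4, 4 percentage points apart, within the scatter of two such steps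

The compounds shown leave open how a nitrile or a methyl would read in place of the trifluoromethyl, and how an ethyl or a longer chain would read on the oxygen. With a single concentration, they also leave open how these changes would appear as potencies.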